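The source may hold more compounds than are shown below. What is called first, only, known or untested is meant among the compounds shown, and "the series" means these compounds.

Compound 1 `O=C1N=C(N2N=C(c3ccccc3)CC2c2ccccc2O)S/C1=C1/C(=O)Nc2ccccc21` and compound 2 `O=C1N=C(N2N=C(c3ccccc3)CC2c2ccccc2O)S/C1=C1/C(=O)Nc2ccc(Br)cc21` share one core, and compound 3 `COc1ccc(C2=NN(C3=NC(=O)/C(=C4\C(=O)Nc5ccccc54)S3)C(c3ccc(Cl)cc3)C2)cc1` and compound 4 `COc1ccc(C2=NN(C3=NC(=O)/C(=C4\C(=O)Nc5ccc(Br)cc54)S3)C(c3ccc(Cl)cc3)C2)cc1` share another; how the two cores differ is not broken down here. In a functional assay on cells (Leukemia cell, Homo sapiens) for cytotoxicity, read by sulforhodamine B assay, with a stated time of 48 h (on this read-out higher numbers stand for weaker inhibition of growth and lower numbers for stronger inhibition of growth), compound 1 gives 3190 nM, compound 2 gives 270 nM, and compound 3 gives 86600 nM. The change bromo in place of hydrogen on an aromatic carbon brought a 12-fold lower number from compound 1 to compound 2 (1.07 log units; beyond the scatter). Compound 4 carries the same change, (bromo in place of hydrogen on an aromatic carbon), on the core of compound 3. Since the change is the same in kind and place, the step is expected to be similar, a 9.6-fold lower number from compound 3 to compound 4 (0.98 log units; beyond the scatter), though the core of compound 3 may respond differently. Compound 4 is therefore estimated at 9000 nM in this assay, within a range from 2500 nM to 35000 nM.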

Compound 4, concentration for 50% growth inhibition: 190 nM
Beside the measured number, compound 4's estimate is 47-fold (1.68 log units) above it; measured number below the stated range.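

Bromo in place of hydrogen on an aromatic carbon gave a 460-fold lower number from compound 3 to compound 4 (2.66 log units; beyond the scatter) and so, as on the core of compound 1, stronger inhibition of growth. The direction of the step carried over from one core to the other, but its size did not: the same change on two cores in this assay, a 12-fold lower number (1.07 log units; beyond the scatter) from compound 1 to compound 2 and a 460-fold lower number (2.66 log units; beyond the scatter) from compound 3 to compound 4, 39-fold (1.59 log units) apart, beyond the scatter of two such steps. In these two cores, a step measured on one core therefore points the right way but does not fix the size on the other, and the data do not show what causes the gap or how the change would behave on a third core.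

Still open, on these data alone, is whether an amine or a carboxylic acid in place of the bromo would give a similar step. Also open, as far as these compounds go, is which difference between the two cores sets the size of the step.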